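Swapping benzylamino for methylsulfanyl on a nucleoside core

A few compounds are considered here, and "the series" means these few. Any claim that something is new, unique, unknown or untested is made for them only; others in the source may bear on it.

Measured compounds:
compound 1 `OC[C@H]1O[C@@H](n2cnc3c(NCc4ccccc4)nccc32)C[C@@H]1O`: 15%
compound 2 `CCNc1nccc2c1ncn2C1O[C@H](CO)[C@@H](O)[C@H]1O`: 4%

Both compounds were tested in a functional assay (Homo sapiens) for inhibition of Nucleic Acid, tested at 100 uM; on this read-out higher numbers stand for more inhibition at the one concentration tested (going by the name of the read-out) and lower numbers for less inhibition. Compound 1 gives 15% and stands highest of the two numbers; compound 2 gives 4%, a value lower by more than the usual scatter. Neither number is large, so both compounds inhibit only weakly at the single concentration tested.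

Compound 3 `CSc1nccc2c1ncn2[C@H]1C[C@H](O)[C@@H](CO)O1` has not yet been measured. It differs from compound 1 in one place: methylsulfanyl in place of benzylamino on an aromatic carbon. Among the compounds with values here, no pair of measured compounds differing in one place is available, so the size of this step has to be judged from the two values alone. Compound 2, which also lacks the benzylamino group, gives the lower value 4%; on that showing the change in compound 3 is expected to lower the value in this assay by a step roughly at the edge of the scatter, not to raise it. The expected step is a number 9 percentage points lower from compound 1 to compound 3 (within the scatter). Compound 3 is therefore estimated at 6%, with a likely range from -8% to 20%.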

Compound 3, a percentage reported as inhibition, at one concentration (the size of the read-out at that concentration, not a potency): 36%
Beside the measured number, compound 3's estimate is 30 percentage points below it, and the stated range ends below it.
By their numbers in this assay, from the lowest: compound 2; then compound 1; then compound 3.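

Within the data shown here, replacing benzylamino with methylsulfanyl on the aromatic carbon next to the ring nitrogen gives a number 21 percentage points higher from compound 1 to compound 3 (beyond the scatter) in this assay, the first direct reading of what a change at this position does. The benzylamino group, with its carbon-only aromatic ring and its hydrogen-bond donor, is therefore not required for inhibition on this core: compound 3 has no ring and no hydrogen-bond donor in that place, and has fewer heavy atoms there, yet it reads higher. Since the ring, the donor and the sulfur all change in this one swap, the step alone cannot show which of them matters, and no measurement here explains the rise.

From the compounds shown here alone, it remains open whether the gain comes from the sulfur itself or simply from losing the benzyl group, a question that a plain amino or a methoxy group at the same place could help to separate. A longer chain such as ethylsulfanyl would show whether the higher reading survives when the methylsulfanyl group is extended.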